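Working notes: the step from compound 2 to compound 4

A few compounds are considered here, and "the series" means these few. Any claim that something is new, unique, unknown or untested is made for them only; others in the source may bear on it.

Measured in an assay for inhibition of cytochrome P450 1A1 (Homo sapiens), read by fluorescence, using microsomes, with a stated time of 10 min; on this read-out higher numbers stand for weaker inhibition and lower numbers for stronger inhibition:
compound 1 `COc1cccc(/C=C/C(=O)c2ccc[nH]2)c1` gives 6200 nM.
compound 2 `O=C(O)c1ccc(/C=C/C(=O)c2ccc[nH]2)cc1` gives > 20000 nM, a limit of the assay rather than a number (the limit of > 20000 nM in this assay, at which 1 of the 3 values shown sits).
compound 3 `COc1cccc(/C=C/C(=O)c2ccc[nH]2)c1OC` gives 5200 nM.
compound 4 `COc1ccc(/C=C/C(=O)c2ccc[nH]2)cc1` is not yet measured.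

Among the measured compounds shown here, compound 2 stands at the limit (the limit of > 20000 nM in this assay, at which 1 of the 3 values shown sits), the only one of the three values without a number; compound 1 and compound 3 both sit at numbers. The change to compound 4 is methoxy in place of carboxy on an aromatic carbon. For the measured compounds named here, the single measured step is a 1.2-fold lower number from compound 1 to compound 3 (0.08 log units; within the scatter), which adds a methoxy and stays within the scatter; it does not remove a carboxy, so it bears only loosely on the present step. What compound 1 and compound 3 do show is where methoxy-bearing members of the series sit in this assay, and compound 4 carries a methoxy as they do. A move toward stronger inhibition is therefore expected, an at least 3.0-fold lower number from compound 2 to compound 4 (0.48 log units; beyond the scatter), its size left open by the limit at which compound 2 stands. Because compound 1 gives 6200 nM and compound 3 gives 5200 nM, compound 4 is expected to give 6500 nM in this assay, within 2500 nM to 18000 nM.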

Compound 4, half-maximal inhibitory concentration: > 20000 nM
Compound 4 was reported as a limit; the forecaster's own chance of this, stated with the estimate: 15%; at least 3.0-fold (0.48 log units) between middle value and limit.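

In this assay compound 2 and compound 4 both stand at a limit of the assay rather than at a number, so no step can be read between them: the limit of > 20000 nM in this assay, at which 2 of the 4 values shown sit.

The compounds shown leave open whether methoxy in place of carboxy on an aromatic carbon changes inhibition in this assay at all, and in which direction.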